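This account rests on a few compounds, and the source may have more. Where it says the series, first, only, none or still open, it means among the compounds named here.

Compound 2 `COc1ccc(CNc2nc3cc(N)cc(N)c3nc2-c2ccccc2)cc1OC` gives 11500 nM in a functional assay on IGROV-1 cells (Homo sapiens) for inhibition, read by sulforhodamine B assay, with a stated time of 48 h; a lower number here means a stronger inhibitor of growth, a higher number a weaker inhibitor of growth; compound 1 `Nc1cc(N)c2nc(-c3ccccc3)c(Oc3ccc(Cl)c(Cl)c3)nc2c1` gives 11500 nM in this assay, level with compound 2 at the digits shown, and the two together are the highest of the three numbers. Compound 3 `COc1cc(CNc2nc3cc(N)cc(N)c3nc2-c2ccccc2)cc(OC)c1OC` gives 9120 nM, the step of a 1.3-fold lower number from compound 2 to compound 3 (0.10 log units; within the scatter) lying within the scatter. Compound 4 `COc1ccc(CNc2nc3cc(N)cc(N)c3nc2-c2ccccc2)cc1` differs from compound 2 by hydrogen in place of methoxy on an aromatic carbon, which read one bond further out is 3,4-dimethoxyphenyl to 4-methoxyphenyl. Within the data shown here, the only measured step that bears on this is the methoxy-for-hydrogen change a 1.3-fold lower number from compound 2 to compound 3 (0.10 log units; within the scatter), which stayed within the scatter; the change in the opposite sense is therefore expected to move this assay no further. Compound 4 is expected at 11500 nM, range 5500 nM to 24000 nM, a step of no change at the digits printed from compound 2 to compound 4 (within the scatter) expected to stay within the scatter.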

Compound 4, concentration for 50% growth inhibition: 12900 nM
Beside the measured number, compound 4's estimate is 1.1-fold (0.05 log units) below it; the measured number falls inside the stated range.
By their numbers in this assay, from the lowest: compounds 3, 1, 2 and 4 (each within the scatter of the next).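

Going from 3,4-dimethoxyphenyl to 4-methoxyphenyl gives, in this assay, a 1.1-fold higher number from compound 2 to compound 4 (0.05 log units; within the scatter), so this position tolerates hydrogen in place of methoxy without a reading beyond the scatter. With a 1.3-fold lower number from compound 2 to compound 3 (0.10 log units; within the scatter), methoxy has now been both removed from and added to this ring, and neither step leaves the scatter. No measurement shown offers a reason for this flat reading.

Still open, as far as these compounds go, is whether a different group at this position, such as an amine, a carboxylic acid or a longer alkoxy chain, would move the number beyond the scatter. Also open is whether the remaining methoxy matters, since the unsubstituted phenyl ring does not appear among these compounds.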